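Pyrimidinyl to Phenyl on the Thioether Chain Carbon

The compounds below may be only part of what the source reports. "The series", "measured", "known", "first", "only" and "open" are said of these compounds alone.

Compound 1: `CC(C)C(Sc1nc2c(cnn2C)c(=O)n1-c1ccccc1)c1ccccc1`, 130 nM
Compound 2: `CC(Sc1nc2c(cnn2C)c(=O)n1-c1ccc(C#N)cc1)c1ccccc1`, 200 nM
Compound 3: `CC(Sc1nc2c(cnn2C)c(=O)n1-c1ccccc1)c1cncnc1`, 100 nM

All three compounds were tested in an assay on isolated protein for inhibition of Retinaldehyde dehydrogenase 3 (Homo sapiens); on this read-out higher numbers stand for weaker inhibition and lower numbers for stronger inhibition. Compound 3 sits at the low end of the three numbers, yet compound 1 and compound 2 both lie within the usual scatter of it, so no real separation among the three is established. Compound 4, `CC(Sc1nc2c(cnn2C)c(=O)n1-c1ccccc1)c1ccccc1`, is not yet measured. It differs from compound 3 in one place: phenyl in place of pyrimidin-5-yl on a saturated chain carbon bound to a saturated chain carbon and a sulfur. Within the data shown here, no measured pair shows this exact change. Compound 1, which also carries a phenyl on that chain carbon, gives 130 nM, so the step from compound 3 to compound 4 is expected to stay within the scatter, a 1.3-fold higher number from compound 3 to compound 4 (0.11 log units; within the scatter). Compound 4 is therefore estimated at 130 nM, with a range from 50 nM to 350 nM.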

Compound 4, half-maximal inhibitory concentration: 73 nM
The estimate for compound 4 lay 1.8-fold (0.25 log units) above the measured number; the measured number falls inside the stated range.
By their numbers in this assay, from the lowest: compounds 4, 3, 1 and 2 (each within the scatter of the next, the first and the last beyond it).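

Phenyl in place of pyrimidin-5-yl gives a 1.4-fold lower number from compound 3 to compound 4 (0.14 log units; within the scatter) in this assay, so the two ring nitrogens can be exchanged for carbon with no change that stands out from the scatter. Among these compounds, compound 4 also completes two other single-place comparisons: hydrogen in place of cyano gives a 2.7-fold lower number from compound 2 to compound 4 (0.44 log units; beyond the scatter) and is the only one of these steps beyond the scatter, whereas methyl in place of isopropyl gives a 1.8-fold lower number from compound 1 to compound 4 (0.25 log units; within the scatter) and is not. No measurement shown here explains these steps. From the compounds shown here alone, it remains open how an amine on that aromatic carbon, or a longer chain in place of the methyl, would behave.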